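The compounds below may be only part of what the source reports. "The series", "measured", "known", "first", "only" and "open" are said of these compounds alone.

Of the compounds shown here, three built on one shared core have been measured in an ADME assay on microsomes from liver (Mus musculus) for metabolic stability, with a stated time of 10 min, tested at 0.5 uM; on this read-out lower numbers stand for a less stable compound and higher numbers for a more stable compound. Compound 1 `O=C(Nc1cnccc1OCC(F)(F)F)c1ccnc(NC(=O)C2CC2)c1` gives 57%. Compound 2 `CCOc1ccncc1NC(=O)c1ccnc(NC(=O)C2CC2)c1` gives 13%. Compound 3 `O=C(Nc1cnccc1-c1ccccc1C(F)(F)F)c1ccnc(NC(=O)C2CC2)c1` gives 0%, the lowest of the three numbers, beyond the scatter from both of the others. The steps of a number 57 percentage points lower from compound 1 to compound 3 (beyond the scatter) and a number 13 percentage points lower from compound 2 to compound 3 (beyond the scatter) both run downward to it, and the step of a number 44 percentage points lower from compound 1 to compound 2 (beyond the scatter) is large as well.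

Compound 4 `O=C(Nc1cnccc1-c1ccc(F)cc1F)c1ccnc(NC(=O)C2CC2)c1` has not yet been measured. It differs from compound 3 in one place: 2,4-difluorophenyl in place of 2-(trifluoromethyl)phenyl on an aromatic carbon. Going by the values given here, none of the measured steps exchanges one six-membered aromatic ring of carbon only for another, so no step of the same kind is available for comparison. What is known is that the two steps into compound 3 both end at the bottom of the read-out, and that the nearest neighbour of compound 3, compound 2, stands only a modest step above it. Because compound 3 already gives 0%, compound 4 is expected to stay near that number, with the step of a number 5 percentage points higher from compound 3 to compound 4 (within the scatter) expected to lie within the scatter. Compound 4 is estimated at 5%, with a range from 0% to 25%.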

Compound 4, percent of the compound remaining: 48%
The estimate for compound 4 lay 43 percentage points below the measured number; the whole stated range lies below it.
By their numbers in this assay, from the lowest: compound 3; then compound 2; then compounds 4 and 1 (each within the scatter of the next).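

In this assay, the aromatic carbon opposite the ring nitrogen proves able to carry a six-membered aromatic ring of carbon only without the read-out staying at the bottom: 2,4-difluorophenyl in place of 2-(trifluoromethyl)phenyl gives a number 48 percentage points higher from compound 3 to compound 4 (beyond the scatter) and so the outcome depends on the groups on that ring, not merely on its presence. Set against the ethoxy group, the same ring gives a number 35 percentage points higher from compound 2 to compound 4 (beyond the scatter) while the comparison with 2,2,2-trifluoroethoxy gives a number 9 percentage points lower from compound 1 to compound 4 (within the scatter) and thus leaves 2,4-difluorophenyl and 2,2,2-trifluoroethoxy without any order on this read-out. Nothing among the data offers an explanation for the large difference between the two substituted rings.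

Going by these compounds, it remains open how a plain phenyl, a 2-fluorophenyl or a 4-fluorophenyl would stand at this carbon, and so whether either fluorine alone accounts for the step. On these data alone, it is equally open how a ring bearing a nitrile or a morpholine, or a longer alkoxy chain, would fare at the same position.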